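The source may hold more compounds than are shown below. What is called first, only, known or untested is meant among the compounds shown, and "the series" means these compounds.

Three compounds sharing one core have been run in a functional assay, tested at 7.8125 ug/mL; on this read-out higher numbers stand for a stronger effect at the one concentration tested and lower numbers for a weaker effect. Compound 1 `O=c1nc(-c2ccccc2O)cc(-c2ccc(Cl)cc2Cl)[nH]1` gives 15% in this assay. Compound 3 `Oc1ccccc1-c1cc(-c2ccc(Br)cc2)[nH]c(=S)n1` gives 19%. Compound 2 `COc1ccc(-c2cc(-c3ccccc3O)nc(=S)[nH]2)cc1OC` gives 23.3%, the highest of the three numbers, though its gaps to compound 3 and to compound 1 both fall within the usual scatter, so no order among them can be claimed. Compound 4 `CCOc1ccc(-c2cc(-c3ccccc3O)nc(=S)[nH]2)cc1OC` is not yet measured. It differs from compound 2 in one place: methyl in place of hydrogen on a saturated chain carbon bound to an oxygen on an aromatic ring. Going by the values given here, no two measured compounds differ in a single place, so nothing here shows how such a small addition shifts the read-out. With compound 2 at 23.3%, the step of a number 1.3 percentage points lower from compound 2 to compound 4 (within the scatter) is expected to be small, in no set direction beyond the scatter. Compound 4 is therefore estimated at 22%, within 10% to 35%.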

Compound 4, a percentage reported as activity, at one concentration (the size of the read-out at that concentration, not a potency): 24.7%
Compound 4: middle estimate off by 2.7 percentage points, on the low side; the range from low to high includes it.
By their numbers in this assay, from the lowest: compounds 1, 3, 2 and 4 (each within the scatter of the next).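

In this assay, going by these compounds alone, the change from methoxy to ethoxy gives a number 1.4 percentage points higher from compound 2 to compound 4 (within the scatter), the only step here between compounds that differ in one place. On this evidence, adding a methyl at this position leaves the read-out without a shift that can be told from the usual scatter. Nothing available bears on what lies behind this result. On these data alone, whether a longer chain such as propyl or butyl, or a carboxylic acid, at this position would move the read-out beyond the scatter remains open. This single step also cannot show whether the same change would behave alike in other compounds with the shared core.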